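A few compounds are considered here, and "the series" means these few. Any claim that something is new, unique, unknown or untested is made for them only; others in the source may bear on it.

- Compound 1 `CCOc1cc(NC(=O)NCc2cc(C)c(-c3cn(C)nc3C(F)(F)F)cn2)cc(Cl)n1`: 150 mL/min/kg
- Compound 2 `Cc1cc(CNC(=O)Nc2cc(OCC(O)CO)nc(C(F)(F)F)c2)nnc1-c1cn(C)nc1C(F)(F)F`: 31.7 mL/min/kg

In an ADME assay on microsomes from liver (Homo sapiens) for metabolic stability, read by LC-MS, with a stated time of 4 h, tested at 1 uM (a higher number here means faster removal of the compound, a lower number slower removal), compound 2 gives 31.7 mL/min/kg, the lower of the two numbers and clearly beyond the usual scatter from compound 1. Compound 3 `Cc1cc(CNC(=O)Nc2cc(OCCO)nc(C(F)(F)F)c2)nnc1-c1cn(C)nc1C(F)(F)F` differs from compound 2 in one place: hydrogen in place of hydroxymethyl on a saturated chain carbon bound to an oxygen on a saturated carbon and a saturated chain carbon. Hydrogen replaces hydroxymethyl on a saturated chain carbon, so 2,3-dihydroxypropoxy becomes 2-hydroxyethoxy. Among the compounds with values here, no measured pair shows this change, so the expectation is uncertain, and no step beyond the scatter is expected. The estimated change is a 1.1-fold higher number from compound 2 to compound 3 (0.04 log units; within the scatter). The expected value for compound 3 is 35 mL/min/kg, with an estimated range of 18 mL/min/kg to 68 mL/min/kg.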

Compound 3, clearance: < 23.4 mL/min/kg
Compound 3 gave a limit, no number (the forecaster's own chance of this, stated with the estimate: 3%); middle value at least 1.4-fold (0.17 log units) away from the limit.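

In this assay, within the data shown here, the first change confined to this chain, 2,3-dihydroxypropoxy to 2-hydroxyethoxy, gives an at least 1.3-fold lower number from compound 2 to compound 3 (0.13 log units; that floor lies within the scatter). Losing the hydroxymethyl therefore does not speed removal, so it is not needed to keep removal slow. The step is only a floor because compound 3 gave a limit of the assay, not a number: the limit of < 23.4 mL/min/kg in this assay, at which 1 of the 3 values shown sits.

As far as these compounds go, how much slower compound 3 is removed than compound 2 remains open. So does whether an amine or a longer chain, such as 3-hydroxypropoxy, would keep removal this slow.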